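The compounds below may be only part of what the source reports. "The series", "measured", "known", "first", "only" and "open" are said of these compounds alone.

Measured so far in a functional assay on RAW264.7 cells (Mus musculus) for inhibition, read by Griess assay, with stated times of 2 h and 24 h; on this read-out higher numbers stand for weaker inhibition and lower numbers for stronger inhibition:
compound 1 `C#CCOc1cc(O)c2c(c1)O[C@H](c1ccc(OC)c(O)c1)CC2=O` — 20900 nM
compound 2 `COc1ccc([C@@H]2CC(=O)c3c(O)cc(OCc4cn(CC5CC5)nn4)cc3O2)cc1O` — 11900 nM

Among the measured compounds shown here, compound 2 is the only compound besides compound 1 with a number in this assay, and the two sit within the scatter of each other: a 1.8-fold lower number from compound 1 to compound 2 (0.24 log units; within the scatter). On the numbers shown, compound 2 therefore has no neighbour from which it is separated beyond the scatter.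

Compound 3 `COc1ccc([C@@H]2CC(=O)c3c(O)cc(OCc4cn(Cc5ccc(C)cc5)nn4)cc3O2)cc1O` is the next member of the series. It differs from compound 2 in one place: 4-methylphenyl in place of cyclopropyl on a saturated chain carbon bound to an aromatic nitrogen. For the measured compounds named here, the only measured step, from compound 1 to compound 2, exchanged the group on the saturated chain carbon bound to the oxygen on the aromatic ring, and it stayed within the scatter. Going by the values given here, no measured step touches the substituent on the triazole nitrogen, so the change to compound 3 is not directly covered by the data. Among the compounds with values here, with the one step available being flat, the working expectation is a step of no clear direction. The step this means, a 1.2-fold lower number from compound 2 to compound 3 (0.08 log units; within the scatter), is estimated to stay within the scatter, with a wide range to reflect the lack of a precedent. Compound 3 is accordingly estimated at 10000 nM, between 3000 nM and 35000 nM.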

Compound 3, half-maximal inhibitory concentration: 16800 nM
Compound 3: middle estimate off by 1.7-fold (0.23 log units), on the low side; the measured number falls inside the stated range.
By their numbers in this assay, from the lowest: compounds 2, 3 and 1 (each within the scatter of the next).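

In this assay, the substituent on the saturated chain carbon bound to an aromatic nitrogen now has its first measured step: cyclopropylmethyl to 4-methylbenzyl gives a 1.4-fold higher number from compound 2 to compound 3 (0.15 log units; within the scatter), which lies within the scatter. Exchanging a three-membered non-aromatic ring of carbon only for a six-membered aromatic ring of carbon only, with 7 heavy atoms entering where 3 leave, therefore does not separate compound 2 at 11900 nM from compound 3 at 16800 nM, so this position accepts both groups on this read-out. No measurement bears on why the two compounds stay this close.

Still open, from the compounds shown here alone, is whether a group of another kind on that chain carbon, such as a primary amine or a carboxylic acid, or a longer chain in place of that single carbon, would give a step beyond the scatter in this assay. Also open, going by these compounds, is what the methyl of the 4-methylphenyl group contributes, a question that a plain phenyl or a 4-methoxyphenyl group at the same place would address.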